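Bromo in Place of Hydrogen on a Second Core

The source may hold more compounds than are shown below. What is called first, only, known or untested is meant among the compounds shown, and "the series" means these compounds.

Measured compounds:
compound 1, `CC(C)OC(=O)c1c(NC(=S)Nc2cccc3ccccc23)sc2c1CCC2`, compound 1 gives 180 nM
compound 2, `CC(C)OC(=O)c1c(NC(=S)Nc2cccc3ccccc23)sc2c1CCCC2`, compound 2 gives 140 nM
compound 3, `CC(C)OC(=O)c1c(NC(=S)Nc2ccc(Br)c3ccccc23)sc2c1CCC2`, compound 3 gives 39 nM

The three measured compounds were tested in an assay on HEK-Blue hTLR2 cells for agonist activity at Toll-like receptor 2 (Homo sapiens), with a stated time of 24 h; a lower number here means that less compound is needed, a higher number that more compound is needed for the effect. Compound 1 and compound 2 share most of their structure, but the difference between their two cores is not broken down here; their values lie within the scatter of each other, so nothing is said about their order. Compound 3 is compound 1 with one change, (bromo in place of hydrogen on an aromatic carbon), and this brought a 4.6-fold lower number from compound 1 to compound 3 (0.66 log units; beyond the scatter).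

Compound 4, `CC(C)OC(=O)c1c(NC(=S)Nc2ccc(Br)c3ccccc23)sc2c1CCCC2`, is not yet measured in this assay. It stands to compound 2 as compound 3 stands to compound 1: the change is bromo in place of hydrogen on an aromatic carbon, and it sits at the same place, described in the same words, as the change from compound 1 to compound 3. It is therefore the same change, made on the core of compound 2 rather than the core of compound 1.

Because a 4.6-fold lower number from compound 1 to compound 3 (0.66 log units; beyond the scatter) was beyond the scatter, a step of similar size is expected here; the estimate for compound 4 means a 4.4-fold lower number from compound 2 to compound 4 (0.64 log units; beyond the scatter), resting on the value of compound 2, 140 nM, as its starting point. Going by the values given here, compound 4 is thus expected to give about 32 nM in this assay, with a likely range from 14 nM to 75 nM, the width reflecting that only one earlier example of this change is known.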

Compound 4, half-maximal effective concentration: 48 nM
Compound 4: middle estimate off by 1.5-fold (0.18 log units), on the low side, and the stated range covers the measured number.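

In this assay, bromo in place of hydrogen on an aromatic carbon brought a 2.9-fold lower number from compound 2 to compound 4 (0.46 log units; beyond the scatter). Set beside the earlier step, this shows that the change lowered the number on both cores, and that the two steps cannot be told apart in size: the same change on two cores in this assay, a 4.6-fold lower number (0.66 log units; beyond the scatter) from compound 1 to compound 3 and a 2.9-fold lower number (0.46 log units; beyond the scatter) from compound 2 to compound 4, 1.6-fold (0.20 log units) apart, within the scatter of two such steps. It does not show that the second core weakens the effect of the change, since the gap between the steps is no larger than such steps can differ by chance; nor does a single pair of cores show that the change would carry to any further core in the series, or say why the bromo has this effect.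

The compounds shown leave open whether the effect belongs to bromo in particular or would also come with a chloro, a methyl or a methoxy group at the same place on the ring. They also leave open how the change would behave if the ester were replaced by a carboxylic acid or an amide, and whether the two steps would still agree in any other assay.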